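Swapping cyano for chloro on compound 1

The source may report more compounds than this note shows. Statements on the series, on what has been measured and on what is new or still open speak of the compounds shown alone.

Measured values:
compound 1 `N#Cc1cnc(NC(=O)CCCOc2ccccc2)s1`: 1100 nM
compound 2 `Cc1cnc(NC(=O)CCCOc2cccc(Cl)n2)s1`: < 1200 nM (a limit)
compound 3 `Cc1cnc(NC(=O)NCCOc2ccc(Cl)c(C)c2)s1`: 1600 nM

In a physicochemical assay for solubility, read by nephelometry, at pH 2 (on this read-out higher numbers stand for higher solubility and lower numbers for lower solubility), compound 1 gives 1100 nM, and this lies within the usual scatter of compound 3 at 1600 nM. For compound 2, the value < 1200 nM is a limit of the assay and not a number.

Compound 4 `O=C(CCCOc1ccccc1)Nc1ncc(Cl)s1` has not been measured yet. It keeps the rest of compound 1 and carries chloro in place of cyano on an aromatic carbon.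

Among the compounds with values here, no measured pair of compounds shows what this swap does. The expectation therefore starts from compound 1 at 1100 nM and stays cautious: a small move toward lower numbers in this assay, probably not beyond the scatter. The estimated change is a 1.4-fold lower number from compound 1 to compound 4 (0.14 log units; within the scatter). Compound 4 is expected to give about 800 nM, with an estimated range of 300 nM to 2000 nM.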

Compound 4, solubility: < 1200 nM
Compound 4: only a limit was reported; the forecaster's own chance of this, stated with the estimate: 30%; the middle value lies beyond the limit too.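

In this assay compound 4 gives < 1200 nM, which is a limit of the assay and not a number. The size of the step between compound 1 and compound 4 therefore cannot be read: the limit of < 1200 nM in this assay, at which 2 of the 4 values shown sit.

The compounds shown leave open whether chloro in place of cyano on an aromatic carbon changes the number in this assay at all, and by how much.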